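Cyclopentyl in Place of Neopentyl: an Expectation for Compound 4

A few compounds are considered here, and "the series" means these few. Any claim that something is new, unique, unknown or untested is made for them only; others in the source may bear on it.

Compound 1 `CC(C)(C)CCc1cnc(CCc2ccc(-c3ccccc3C(=O)O)cc2)[nH]1` — 6.2 nM
Compound 2 `CCCCc1cnc(Cc2ccc(-c3ccccc3C(=O)O)cc2)[nH]1` — > 10000 nM
Compound 3 `CCC(C)(C)Cc1c[nH]c(CCc2ccc(-c3ccccc3C(=O)O)cc2)n1` — 9.6 nM

In an in vitro functional assay on cells for agonist activity at Bombesin receptor subtype-3 (Mus musculus), read by luminescence and calcium flux (on this read-out higher numbers stand for an effect only at larger amounts of compound and lower numbers for an effect already at smaller amounts), compound 1 gives 6.2 nM, the lowest of the two numbers available. Compound 3 gives 9.6 nM, which lies within the scatter of compound 1, so the two cannot be ranked against each other. For compound 2 the assay reports no number but a limit, > 10000 nM, and the same holds for (the limit of > 10000 nM in this assay, at which 1 of the 3 values shown sits).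

Compound 4 `O=C(O)c1ccccc1-c1ccc(CCc2ncc(CC3CCCC3)[nH]2)cc1` has not yet been measured. It differs from compound 1 by cyclopentyl in place of neopentyl on a saturated chain carbon bound to an aromatic carbon. Among the measured compounds shown here, no measured pair of compounds shows a change of this kind, so the size of the step has to be estimated from the general picture: compound 1 and compound 3 carry branched saturated chains of similar bulk at this place and give numbers within the scatter of each other, and a cyclopentyl group of the same atom count is expected to behave in much the same way. The step of a 1.9-fold higher number from compound 1 to compound 4 (0.29 log units; within the scatter) is therefore expected to be small, if anything toward a higher number. Compound 4 is expected to give about 12 nM, with a likely range from 3 nM to 50 nM.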

Compound 4, half-maximal effective concentration: 7.9 nM
Compound 4: the middle estimate sits 1.5-fold (0.18 log units) above what was measured; low and high end bracket the measured number.
By their numbers in this assay, from the lowest: compounds 1, 4 and 3 (each within the scatter of the next). At a limit, above all of these: compound 2.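

Cyclopentyl in place of neopentyl on a saturated chain carbon bound to an aromatic carbon gives a 1.3-fold higher number from compound 1 to compound 4 (0.11 log units; within the scatter) in this assay. This is the only measured pair shown in which nothing but this group changes, and it shows that a five-membered non-aromatic ring of carbon only can take the place of the open branched group without a step beyond the scatter. The data shown offer no reason for this result.

What the compounds leave open is whether a larger ring such as cyclohexyl, or an aromatic ring such as phenyl, would give a number of this size at this place. On these data alone, it also remains open how a chain carrying an amine or a hydroxyl group would read out in this assay.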